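Replacing the methoxy-bearing aryl group in compound 2

This account rests on a few compounds, and the source may have more. Where it says the series, first, only, none or still open, it means among the compounds named here.

The measured compounds in a functional assay on U-251 cells (Homo sapiens) for cytotoxicity; a higher number here means a weaker inhibitor of growth, a lower number a stronger inhibitor of growth:
compound 1, `COc1ccc(C2=C(c3ccc(SC)cc3)CC3CCCN3C2=O)cc1Br`, gives 800 nM.
compound 2, `COc1ccc(C2=C(c3ccc(SC)cc3)CC3CCCN3C2=O)cc1C`, gives 90 nM.
compound 3, `CSc1ccc(C2=C(c3ccc(O)cc3)C(=O)N3CCCC3C2)cc1`, gives only a limit of the assay, > 100000 nM; this is the limit (the limit of > 100000 nM in this assay, at which 1 of the 3 values shown sits).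

Compound 2 has the lowest of the two numbers; its nearest neighbour is compound 1, with an 8.9-fold lower number from compound 1 to compound 2 (0.95 log units; beyond the scatter). Compound 4, `CSc1ccc(C2=C(c3ccc(SC)cc3)C(=O)N3CCCC3C2)cc1`, is not yet measured in this assay. Its change from compound 2 is 4-(methylsulfanyl)phenyl in place of 4-methoxy-3-methylphenyl on a double-bonded ring carbon.

Among the compounds with values here, no measured step makes exactly this change. The nearest is the step of an at least 1100-fold higher number from compound 2 to compound 3 (3.04 log units; beyond the scatter), which alters the same group on the same double-bonded ring carbon and ends at a limit; the step of an at least 120-fold higher number from compound 1 to compound 3 (2.09 log units; beyond the scatter) does likewise. The smaller step of an 8.9-fold lower number from compound 1 to compound 2 (0.95 log units; beyond the scatter) touches only a substituent on that ring. Because an at least 1100-fold higher number from compound 2 to compound 3 (3.04 log units; beyond the scatter) shows a large loss when the 4-methoxy-3-methylphenyl is exchanged, a loss beyond the scatter is expected for compound 4, though smaller than for compound 3, since the entering 4-(methylsulfanyl)phenyl already appears on the ring atom that bears it in every measured compound. The expected step is a 22-fold higher number from compound 2 to compound 4 (1.35 log units; beyond the scatter). Compound 4 is therefore estimated at 2000 nM, within 200 nM to 40000 nM.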

Compound 4, concentration for 50% growth inhibition: 5000 nM
Estimate against measurement, compound 4: 2.5-fold (0.40 log units) below; measured number inside the range.
By their numbers in this assay, from the lowest: compound 2; then compound 1; then compound 4. At a limit, above all of these: compound 3.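

The exchange at this double-bonded ring carbon proves costly but not ruinous: 4-(methylsulfanyl)phenyl in place of 4-methoxy-3-methylphenyl gives a 56-fold higher number from compound 2 to compound 4 (1.74 log units; beyond the scatter), and in place of 3-bromo-4-methoxyphenyl it gives a 6.3-fold higher number from compound 1 to compound 4 (0.80 log units; beyond the scatter), so compound 4 ranks behind both compounds that carry a substituted methoxyphenyl, yet it still returns a real number, which compound 3 does not. The group at the far end of the entering aryl ring therefore matters a great deal, since methylsulfanyl in place of hydroxy on an aromatic carbon gives an at least 20-fold lower number from compound 3 to compound 4 (1.30 log units; beyond the scatter). That step has only a lower bound, as compound 3 gives no number in this assay, only a limit: the limit of > 100000 nM in this assay, at which 1 of the 4 values shown sits.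

The compounds shown leave open whether a plain 4-methoxyphenyl at this carbon would read closer to compound 2 or to compound 4, and so which part of the 4-methoxy-3-methylphenyl group accounts for the gap. They also leave open how an amine or a carboxylic acid on that aromatic ring, or a longer chain such as ethylsulfanyl in place of the methylsulfanyl, would read in this assay.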